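The compounds below may be only part of what the source reports. "The series", "measured", "known", "first", "only" and "open" are said of these compounds alone.

In a functional assay on A549 cells (Homo sapiens) for inhibition, read by MTT assay, with a stated time of 48 h (a higher number here means a weaker inhibitor, a lower number a stronger inhibitor), compound 1 (`COc1ccc2c(=O)c(/C=C/C(=O)Nc3ccccc3)coc2c1`) gives 51000 nM. Compound 2 (`COc1ccc2c(=O)c(/C=C/C(=O)Nc3ccc(Cl)cc3)coc2c1`) gives > 100000 nM. This is a limit of the assay and not a number, so compound 2 has no exact position in the series.

Compound 3 (`COc1ccc2c(=O)c(/C=C/C(=O)NCc3ccc(F)cc3F)coc2c1`) differs from compound 2 as follows: 2,4-difluorobenzyl in place of 4-chlorophenyl on an amide-type nitrogen. Within the data shown here, the only measured step is an at least 1.9-fold higher number from compound 1 to compound 2 (0.29 log units; that floor lies within the scatter). It concerns chloro in place of hydrogen on an aromatic carbon, and its floor lies within the scatter. Among the measured compounds shown here, no measured step covers a change on the amide-type nitrogen, so the expectation rests mainly on compound 1 at 51000 nM. Compound 3 is therefore expected to remain a weak inhibitor in this assay, and a result reported only as a limit remains possible. The expected change is an at least 1.6-fold lower number from compound 2 to compound 3 (0.22 log units; that floor lies within the scatter), a modest move towards a lower number with an uncertain size. For compound 3 the estimate is 60000 nM, with an expected range of 20000 nM to 100000 nM.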

Compound 3, half-maximal inhibitory concentration: 13300 nM
Compound 3: the middle estimate sits 4.5-fold (0.65 log units) above what was measured; measured number below the stated range.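

Among these compounds, on the amide-type nitrogen, replacing phenyl with 2,4-difluorobenzyl gives a 3.8-fold lower number from compound 1 to compound 3 (0.58 log units; beyond the scatter) in this assay, the first step that lies beyond the scatter. Replacing 4-chlorophenyl with 2,4-difluorobenzyl at the same place gives an at least 7.5-fold lower number from compound 2 to compound 3 (0.87 log units; beyond the scatter), so this position can move the number further than the chloro change on the aromatic carbon could be shown to do. Compound 2 stands at a limit of the assay and not a number, so that step is a floor with no known full size: the limit of > 100000 nM in this assay, at which 1 of the 3 values shown sits.

The compounds shown do not tell whether the lower number goes with the benzyl carbon or with the two fluorines, since both enter together. Plain benzyl, 4-fluorobenzyl, a longer chain such as 2-phenylethyl and an aminoalkyl chain on this nitrogen remain open, as does whether any of them goes clearly below compound 3 at 13300 nM.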